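The compounds below may be only part of what the source reports. "The series", "measured", "known", "first", "only" and "open" are said of these compounds alone.

Measured so far in a functional assay on BJAB cells (Homo sapiens) for antiproliferative activity, with a stated time of 4 days; on this read-out lower numbers stand for an effect already at smaller amounts and higher numbers for an effect only at larger amounts of compound:
- compound 1 `Cc1cc(Cl)cc(-c2c(C)nn(-c3nc(-c4ccc(Cl)c(Cl)c4)c(SC(C)C)s3)c2C(=O)O)c1`: 663 nM
- compound 2 `Cc1nn(-c2nc(-c3ccc(Cl)c(Cl)c3)c(SC(C)C)s2)c(C(=O)O)c1Cc1ccccc1[N+](=O)[O-]`: 20000 nM

Compound 2 stands at the highest of the two numbers in this assay; its nearest neighbour is compound 1, and the step of a 30-fold higher number from compound 1 to compound 2 (1.48 log units; beyond the scatter) lies beyond the scatter. That step came from a single change, a 2-nitrobenzyl group taking the place of a 3-chloro-5-methylphenyl group on an aromatic carbon of the core.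

Compound 3 `Cc1nn(-c2nc(-c3ccc(Cl)c(Cl)c3)c(SC(C)C)s2)c(C(=O)O)c1-c1ccccc1` has not been measured. It differs from compound 2 in one place: phenyl in place of 2-nitrobenzyl on an aromatic carbon. This change removes the same 2-nitrobenzyl group whose arrival brought the large rise in number from compound 1 to compound 2, and puts back a phenyl group, as compound 1 also carries a six-membered aromatic ring of carbon only at that place, though with chloro and methyl substituents that compound 3 lacks. Among the measured compounds shown here, the only bearing step is therefore the one from compound 1 to compound 2, and its reversal is expected to carry most of the way back. Compound 3 is therefore estimated at 2000 nM in this assay, within a range from 500 nM to 8000 nM, which means an expected step of a 10-fold lower number from compound 2 to compound 3 (1.00 log units; beyond the scatter).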

Compound 3, half-maximal effective concentration: 3000 nM
Compound 3: middle estimate off by 1.5-fold (0.18 log units), on the low side; measured number inside the range.
By their numbers in this assay, from the lowest: compound 1; then compound 3; then compound 2.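

All three compounds carry one six-membered aromatic ring of carbon only at this place on the core, yet in this assay they do not read alike, so the ring alone does not settle the number. Going from 2-nitrobenzyl to phenyl gives a 6.7-fold lower number from compound 2 to compound 3 (0.82 log units; beyond the scatter) and thus recovers part of the earlier loss, while replacing 3-chloro-5-methylphenyl with phenyl gives a 4.5-fold higher number from compound 1 to compound 3 (0.66 log units; beyond the scatter) and shows that the bare ring does not match the ring with chloro and methyl substituents, which gives the lowest number of the three. No measurement here accounts for either difference.

The compounds shown do not separate the parts of either change: a phenyl ring carrying only the chloro or only the methyl would show how each substituent contributes on its own. A plain benzyl group would likewise help to tell whether the higher number of compound 2 goes with the nitro group or with the extra carbon that links the ring to the core.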